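Aryl swap on the ring amine of compound 1

The source may report more compounds than this note shows. Statements on the series, on what has been measured and on what is new or still open speak of the compounds shown alone.

Measured compounds:
compound 1, `Cc1ccc(N2CC[C@@H](NC(=O)Nc3ccccc3Br)C2)cc1F`, 8.3
compound 2, `Cc1ccc2c(c1)CCN2CCNC(=O)Nc1ccccc1Br`, 7.3
compound 3, `O=C(NCCN1CCc2c(F)cccc21)Nc1ccccc1Br`, 7.4

In a functional assay for antagonist activity at transient receptor potential cation channel subfamily V member 1 (Rattus norvegicus), read by FLIPR (a higher number here means a more potent compound, by a factor of ten per unit of this negative logarithm, a lower number a less potent compound), compound 1 gives the highest of the three values. Compound 3 comes nearest, a number beyond the scatter below it, and compound 2 lies furthest, also beyond the scatter. Among the measured compounds shown here, compounds 2 and 3 share an open-chain linker between the urea and the ring amine, whereas compound 1 carries the urea on a five-membered non-aromatic ring with 1 nitrogen; no single-point step between measured compounds exists, so none of the gaps can be assigned to one change.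

Compound 4, `Cc1ccc(N2CC[C@@H](NC(=O)Nc3ccccc3Br)C2)nc1`, is not yet measured. It differs from compound 1 in one place: 5-methylpyridin-2-yl in place of 3-fluoro-4-methylphenyl on an amine nitrogen in a ring. For the measured compounds named here, nothing among the measured compounds tests this swap, so the step in this assay is expected to be small, most likely a modest decrease, and it may well stay within the scatter. Compound 4 is therefore estimated at 7.9, with a range from 7.2 to 8.6, which corresponds to an expected step of a number 0.40 log units lower from compound 1 to compound 4 (beyond the scatter).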

Compound 4, negative logarithm of the antagonist equilibrium constant: < 6.7
Compound 4: a limit, no number; the forecaster's own chance of this, stated with the estimate: 5%; middle value at least 1.20 log units away from the limit.
By their numbers in this assay, from the lowest: compounds 2 and 3 (each within the scatter of the next); then compound 1. At a limit, below all of these: compound 4.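

Among the compounds shown here, the ring amine's aryl group is the first place tested by a one-place change, and this swap is not tolerated. In this assay, 5-methylpyridin-2-yl in place of 3-fluoro-4-methylphenyl gives a large drop, a number at least 1.60 log units lower from compound 1 to compound 4 (beyond the scatter), so potency at this position depends strongly on the identity of the aryl group. Compound 4 is recorded only as a limit, so the step is a bound and not an exact size: the limit of < 6.7 in this assay, at which 1 of the 4 values shown sits.

The swap introduces a ring nitrogen and removes the fluorine together, so the compounds shown cannot say which change drives the loss; a plain 4-methylphenyl group on the same ring amine would separate the two. Also open, from the compounds shown here alone, is whether a 5-chloropyridin-2-yl group here would behave any differently from 5-methylpyridin-2-yl.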